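Cytotoxicity after a swap on the amide nitrogen

The source may hold more compounds than are shown below. What is called first, only, known or untested is meant among the compounds shown, and "the series" means these compounds.

In an ADME assay on MT4 cells (Homo sapiens) for cytotoxicity, read by MTT assay (a higher number here means that more compound is tolerated, a lower number that less compound is tolerated), the measured compounds stand as follows:
compound 1 `Cc1cc(C)cc(S(=O)(=O)c2c(C(=O)NC(C)C(=O)NC(C)c3ccncc3)[nH]c3ccc(Cl)cc23)c1` gives 21900 nM;
compound 2 `Cc1cc(C)cc(S(=O)(=O)c2c(C(=O)NCC(=O)NC(C)c3ccncc3)[nH]c3ccc(Cl)cc23)c1` gives 47000 nM;
compound 3 `Cc1cc(C)cc(S(=O)(=O)c2c(C(=O)NCc3n[nH]c4ccccc34)[nH]c3ccc(Cl)cc23)c1` gives > 50700 nM, which is a limit of the assay rather than a number.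

Compound 3 therefore sits at the limit of > 50700 nM in this assay, at which 1 of the 3 values shown sits. Compound 4 `Cc1cc(C)cc(S(=O)(=O)c2c(C(=O)NC(C)c3ccco3)[nH]c3ccc(Cl)cc23)c1` differs from it by 1-(furan-2-yl)ethyl in place of (1H-indazol-3-yl)methyl on an amide-type nitrogen. Within the data shown here, no measured step covers this exact exchange. The step of a 2.1-fold higher number from compound 1 to compound 2 (0.33 log units; beyond the scatter) was a modest shift from a small change on the chain, while an at least 1.0-fold higher number from compound 2 to compound 3 (0.03 log units; that floor lies within the scatter) shows that exchanging a whole end group left the number within the scatter. A similar outcome is expected here, with no step beyond the scatter, an at least 1.1-fold lower number from compound 3 to compound 4 (0.05 log units; that floor lies within the scatter). Compound 4 is accordingly estimated at 45000 nM, between 20000 nM and 60000 nM.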

Compound 4, half-maximal cytotoxic concentration: > 54700 nM
Compound 4: no number, only a limit (the forecaster's own chance of this, stated with the estimate: 45%); at least 1.2-fold (0.08 log units) between middle value and limit.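

In this assay compound 4 also stops at a limit of the assay, not a number: the limit of > 54700 nM in this assay, at which 1 of the 4 values shown sits. With compound 3 at a limit as well, the step between them cannot be read. Even so, the amide nitrogen now carries a smaller group of one five-membered aromatic ring and no hydrogen-bond donor, and the result stays high: an at least 1.1-fold higher number from compound 2 to compound 4 (0.06 log units; that floor lies within the scatter), and an at least 2.4-fold higher number from compound 1 to compound 4 (0.39 log units; beyond the scatter).

Going by these compounds, how compound 3 and compound 4 rank remains open. So does whether a simple benzyl or a chain ending in a carboxylic acid on this nitrogen would give a readable number.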